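Moving the Methyl from Cyano to Carbamoyl Analogs

The compounds below may be only part of what the source reports. "The series", "measured", "known", "first", "only" and "open" are said of these compounds alone.

Four compounds share one core and differ at two points. Compound 1 `Cc1ccccc1-c1nc2cc(-c3nc4cc(C#N)ccc4[nH]3)ccc2[nH]1` carries a cyano group and a 2-methylphenyl group; in a functional assay on RPMI 8402 cells (Homo sapiens) for cytotoxicity (a higher number here means a weaker inhibitor, a lower number a stronger inhibitor), compound 1 gives 1200 nM. Compound 2 `Cc1cccc(-c2nc3cc(-c4nc5cc(C#N)ccc5[nH]4)ccc3[nH]2)c1` differs from compound 1 in one place: 3-methylphenyl in place of 2-methylphenyl on an aromatic carbon. In this assay compound 2 gives 860 nM, and the step is a 1.4-fold lower number from compound 1 to compound 2 (0.14 log units; within the scatter). Compound 3 `Cc1ccccc1-c1nc2cc(-c3nc4cc(C(N)=O)ccc4[nH]3)ccc2[nH]1` differs from compound 1 at the other point: carbamoyl in place of cyano on an aromatic carbon. In this assay compound 3 gives 8200 nM, the highest number of the three, and the step is a 6.8-fold higher number from compound 1 to compound 3 (0.83 log units; beyond the scatter).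

Compound 4 `Cc1cccc(-c2nc3cc(-c4nc5cc(C(N)=O)ccc5[nH]4)ccc3[nH]2)c1` has not been measured. It stands to compound 3 as compound 2 stands to compound 1: 3-methylphenyl in place of 2-methylphenyl on an aromatic carbon. The place of this change is described in the same words for both pairs, so it is the same change, occurring twice among these compounds, and its one measured instance is a 1.4-fold lower number from compound 1 to compound 2 (0.14 log units; within the scatter). Among the compounds with values here, the step expected for compound 4 is a 1.4-fold lower number from compound 3 to compound 4 (0.14 log units; within the scatter), because the single measured instance of the same change a 1.4-fold lower number from compound 1 to compound 2 (0.14 log units; within the scatter) stayed within the scatter. In this assay compound 4 is therefore estimated at 6000 nM, most likely between 2500 nM and 14000 nM. Whether the change behaves the same way on a carbamoyl-bearing core as on a cyano-bearing one rests on a single comparison, so this expectation is held loosely.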

Compound 4, half-maximal inhibitory concentration: 8200 nM
Estimate against measurement, compound 4: 1.4-fold (0.14 log units) below; the measured number falls inside the stated range.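

In this assay, 3-methylphenyl in place of 2-methylphenyl on the carbamoyl-bearing core gives no change at the digits printed from compound 3 to compound 4 (within the scatter), and this step agrees with its counterpart on the cyano-bearing core: the same change on two cores in this assay, a 1.4-fold lower number (0.14 log units; within the scatter) from compound 1 to compound 2 and no change at the digits printed (within the scatter) from compound 3 to compound 4, 1.4-fold (0.14 log units) apart, within the scatter of two such steps. Carbamoyl in place of cyano, now read with the 3-methylphenyl group in place, gives a 9.5-fold higher number from compound 2 to compound 4 (0.98 log units; beyond the scatter), and this step likewise agrees with its counterpart read with the 2-methylphenyl group: the same change on two cores in this assay, a 6.8-fold higher number (0.83 log units; beyond the scatter) from compound 1 to compound 3 and a 9.5-fold higher number (0.98 log units; beyond the scatter) from compound 2 to compound 4, 1.4-fold (0.14 log units) apart, within the scatter of two such steps. Among these four compounds, each change therefore carries from one core to the other with no difference beyond the scatter, the methyl move staying within the scatter on both cores and the carbamoyl change going beyond it on both, but this rests on a single pair of steps for each change and does not show that either step would hold on any other core or in any other assay.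

The compounds shown leave open whether a carboxylic acid or an amine in place of the cyano group would follow the carbamoyl compounds or the cyano compounds. They also leave open whether an ethyl group or a chlorine atom in place of the methyl on the phenyl ring would likewise stay within the scatter.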